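A few compounds are considered here, and "the series" means these few. Any claim that something is new, unique, unknown or untested is made for them only; others in the source may bear on it.

Compound 3 `CCCCNC(=O)CCCOc1cc(C2CNC(=O)C2)ccc1OC` carries a butylamino group on a carbonyl carbon. In an assay on isolated protein for inhibition of phosphodiesterase 1 (Bos taurus), read by cGMP accumulation, in the presence of a further agent that is not named here (on this read-out lower numbers stand for stronger inhibition and higher numbers for weaker inhibition), compound 3 reaches only a limit of the assay, at > 1000000 nM. Compound 1 `COc1ccc(C2CNC(=O)C2)cc1OCCCC(=O)O` likewise gives a limit in this assay, at > 1000000 nM. Compound 2 `CCOC(=O)CCCOc1cc(C2CNC(=O)C2)ccc1OC` also gives a limit there, at > 1000000 nM. The steps among them therefore stay unreadable: a step that the two limits leave unreadable from compound 1 to compound 2, a step that the two limits leave unreadable from compound 1 to compound 3 and a step that the two limits leave unreadable from compound 2 to compound 3. Compound 4 `COc1ccc(C2CNC(=O)C2)cc1OCCCC(=O)N(C)C1CCCCC1` differs from compound 3 by cyclohexyl(methyl)amino in place of butylamino on a carbonyl carbon. Among the measured compounds shown here, no measured step bears readably on this change; the limit of > 1000000 nM in this assay, at which 3 of the 3 values shown sit, is the only evidence available. Compound 4 is therefore expected to remain at that limit as well, with an estimated step that the limit leaves unreadable from compound 3 to compound 4. The estimate for compound 4 in this assay is 2000000 nM, ranging from 200000 nM to 20000000 nM.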

Compound 4, half-maximal inhibitory concentration: > 1000000 nM
Compound 4 ended at the assay's limit; the forecaster's own chance of this, stated with the estimate: 85%; the middle value lies beyond the limit too.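

Compound 4, like compound 1, compound 2 and compound 3, gives only a limit in this assay, so no step among these compounds can be read: the limit of > 1000000 nM in this assay, at which 4 of the 4 values shown sit. The compounds shown leave open which group on the carbonyl carbon, if any, would give a readable value.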